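The source may hold more compounds than are shown below. What is called first, only, known or untested is meant among the compounds shown, and "the series" means these compounds.

Measured so far:
compound 1, `C#CCSc1nc(Nc2ccc(Br)cc2)c2ccncc2n1`: 56200 nM in a functional assay on HepG2 cells (Homo sapiens) for inhibition, read by MTT assay, with a stated time of 72 h; a higher number here means a weaker inhibitor, a lower number a stronger inhibitor
compound 2, `C#CCSc1nc(Nc2ccc([N+](=O)[O-])cc2)c2ccncc2n1`: > 80000 nM in this assay

Compound 2 stands at a limit in this assay: its value of > 80000 nM is not a number but a limit, as shown by the limit of > 80000 nM in this assay, at which 1 of the 2 values shown sits. Compound 3, `C#CCSc1nc(Nc2ccc(OC)cc2)c2ccncc2n1`, differs from compound 2 by methoxy in place of nitro on an aromatic carbon. Among the measured compounds shown here, the one measured step that touches this place is an at least 1.4-fold higher number from compound 1 to compound 2 (0.15 log units; that floor lies within the scatter), which swapped bromo for nitro and ran into the limit; its floor lies within the scatter, so it says little about the size of such exchanges. For the measured compounds named here, no measured compound carries a methoxy at this place, so the step from nitro to methoxy is expected to stay modest, and for compound 3 the expected change is an at least 1.3-fold lower number from compound 2 to compound 3 (0.12 log units; that floor lies within the scatter). Compound 3 is therefore estimated at 60000 nM, within a range from 20000 nM to 160000 nM, with a real chance that only a limit is reported again.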

Compound 3, half-maximal inhibitory concentration: > 80000 nM
Compound 3: no number, only a limit; the forecaster's own chance of this, stated with the estimate: 40%; middle value at least 1.3-fold (0.12 log units) from the limit.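

Compound 3 gives only a limit in this assay, so a second replacement for bromo at this place on the aromatic ring also yields no number: the limit of > 80000 nM in this assay, at which 2 of the 3 values shown sit.

The exchange of bromo for methoxy gives an at least 1.4-fold higher number from compound 1 to compound 3 (0.15 log units; that floor lies within the scatter), so the data do not show whether a real loss lies behind this floor, or how large it might be. The step from compound 2 to compound 3 cannot be read, as both of its ends are limits.

Going by these compounds, it stays open whether any other group at this place, such as an amine or a carboxylic acid, would give a number clearly lower than that of compound 1. Also open, on these data alone, is how a longer chain on the sulfur of the shared core would read in this assay.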